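Ether-linked aryl in place of a chlorofluorophenyl group

A few compounds are considered here, and "the series" means these few. Any claim that something is new, unique, unknown or untested is made for them only; others in the source may bear on it.

Measured compounds:
compound 1 `Cc1nn(-c2ncnc3nc[nH]c23)c2c1C(c1ccc(F)cc1Cl)CC(=O)N2`: 280 nM
compound 2 `Cc1cc(C)n(CCOC2CC(=O)Nc3c2c(C)nn3-c2ncnc3nc[nH]c23)n1`: 2000 nM
compound 3 `COc1ccc(CCOC2CC(=O)Nc3c2c(C)nn3-c2ncnc3nc[nH]c23)cc1`: 70 nM

In a functional assay on HEK293 cells for agonist activity at G-protein coupled receptor 39 (Homo sapiens), read by scintillation proximity assay and inositol phosphate accumulation, with a stated time of 75 min (a higher number here means that more compound is needed for the effect, a lower number that less compound is needed), compound 1 gives 280 nM, the second highest of the three numbers; compound 3 lies nearer, compound 2 furthest. Compound 4 `Cc1nn(-c2ncnc3nc[nH]c23)c2c1C(OCc1ccc(C#N)cc1)CC(=O)N2` has not yet been measured. It differs from compound 1 by one change: (4-cyanobenzyl)oxy in place of 2-chloro-4-fluorophenyl on a saturated ring carbon.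

For the measured compounds named here, two measured steps bear on this. The step of a 7.1-fold higher number from compound 1 to compound 2 (0.85 log units; beyond the scatter) shows that exchanging the directly attached 2-chloro-4-fluorophenyl for an ether-linked group carrying a five-membered aromatic ring costs potency. The step of a 29-fold lower number from compound 2 to compound 3 (1.46 log units; beyond the scatter) shows that an ether-linked group carrying a six-membered carbon-only aromatic ring recovers far more than that loss, so that compound 3 ends up with a lower number than compound 1. Compound 4 carries an ether-linked six-membered carbon-only aromatic ring as well, though with a shorter chain and a nitrile in place of the methoxy group, so a step near or modestly below compound 1 is expected, a 1.9-fold lower number from compound 1 to compound 4 (0.27 log units; within the scatter). Compound 4 is therefore estimated at 150 nM, with a range from 40 nM to 600 nM.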

Compound 4, half-maximal effective concentration: 60 nM
Compound 4: the middle estimate sits 2.5-fold (0.40 log units) above what was measured; measured number inside the range.
By their numbers in this assay, from the lowest: compounds 4 and 3 (each within the scatter of the next); then compound 1; then compound 2.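

In this assay, replacing the directly attached 2-chloro-4-fluorophenyl on this saturated ring carbon with (4-cyanobenzyl)oxy gives a 4.7-fold lower number from compound 1 to compound 4 (0.67 log units; beyond the scatter), so a second ether-linked group with a six-membered carbon-only aromatic ring also gives a lower number than compound 1. The ring substituent and chain length both differ between the two such ethers, yet they cannot be told apart (a 1.2-fold lower number from compound 3 to compound 4 (0.07 log units; within the scatter)), while the ring type again separates them from the pyrazole ether, with a 33-fold lower number from compound 2 to compound 4 (1.52 log units; beyond the scatter). Nothing measured here gives a reason for these steps.

On these data alone, compound 3 and compound 4 differ in both the chain and the ring substituent, so the contribution of each alone remains open. Also open, as far as these compounds go, is how a carboxylic acid in place of the nitrile, or a longer chain between the oxygen and the ring, would read.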